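A Bromine Added to the Styryl Arm of Compound 1

The source may hold more compounds than are shown below. What is called first, only, known or untested is meant among the compounds shown, and "the series" means these compounds.

Compound 1 `CCCC1=C(OC)C(CCC)(CCC)C(=O)/C(=C(O)\C=C\c2ccccc2)C1=O` gives 3.6 uM in a functional assay on A549 cells (Homo sapiens) for antiproliferative activity, read by sulforhodamine B assay, with a stated time of 3 days; a higher number here means that more compound is needed for the effect, a lower number that less compound is needed. Compound 2 `CCCCOC1=C(CCC)C(=O)/C(=C(O)/C=C/c2ccccc2)C(=O)C1(CCC)CCC` gives 7.1 uM in this assay, and of these two numbers compound 1 holds the smaller, though the gap is within the scatter. Going by the values given here, the single measured step, a 2.0-fold higher number from compound 1 to compound 2 (0.29 log units; within the scatter), alters a different part of the molecule. Compound 3 `CCCC1=C(OC)C(CCC)(CCC)C(=O)/C(=C(O)\C=C\c2ccc(Br)cc2)C1=O` differs from compound 1 by bromo in place of hydrogen on an aromatic carbon. Among the compounds with values here, no measured step touches this aromatic position, and nothing here shows how this change moves the number. The expected step is therefore small, within the scatter: a 1.2-fold lower number from compound 1 to compound 3 (0.08 log units; within the scatter). Compound 3 is estimated at 3 uM, between 1 uM and 9 uM.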

Compound 3, concentration for half-maximal effect: 2 uM
For compound 3 the middle estimate is 1.5-fold (0.18 log units) above the measured one; measured number inside the range.
By their numbers in this assay, from the lowest: compounds 3, 1 and 2 (each within the scatter of the next, the first and the last beyond it).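

This is the first change shown on the aromatic ring of the styryl arm: in this assay, going from phenyl to 4-bromophenyl gives a 1.8-fold lower number from compound 1 to compound 3 (0.26 log units; within the scatter). The position therefore accepts a bromine atom with no shift that can be told apart from the scatter of repeated measurements. No available evidence says what lies behind this number.
On these data alone, whether another group here, such as an amine, a carboxylic acid or a methoxy group, would move the number beyond the scatter remains open. So does the effect of bromine elsewhere on this ring.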